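Sulfonamide benzylamide series: notes toward compound 4

The source may report more compounds than this note shows. Statements on the series, on what has been measured and on what is new or still open speak of the compounds shown alone.

Measured so far:
Compound 1, `COc1ccccc1C(=O)NCc1ccc(CNS(=O)(=O)c2cccc(Cl)c2)cc1`, gives 1000 nM in an assay on MDA-MB-231 cells for displacement of a labelled ligand from C-X-C chemokine receptor type 4 (Homo sapiens), read by fluorescence and microscopy, with stated times of 10 min and 30 min; on this read-out lower numbers stand for an effect already at smaller amounts and higher numbers for an effect only at larger amounts of compound.
Compound 2, `COc1ccccc1C(=O)NCc1ccc(CNS(=O)(=O)c2ccccc2F)cc1`, gives 1 nM in this assay.
Compound 3, `Cc1ccccc1C(=O)NCc1ccc(CNS(=O)(=O)c2cccc(Cl)c2)cc1`, gives 100 nM in this assay.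

Compound 4, `Cc1ccccc1C(=O)NCc1ccc(CNS(=O)(=O)c2ccccc2F)cc1`, is not yet measured. It differs from compound 3 in one place: 2-fluorophenyl in place of 3-chlorophenyl on a sulfonyl sulfur. The same change has been made once before, from compound 1 to compound 2: 2-fluorophenyl in place of 3-chlorophenyl on a sulfonyl sulfur. That step gave a 1000-fold lower number from compound 1 to compound 2 (3.00 log units; beyond the scatter). The two cores on which the change sits differ as follows: methyl in place of methoxy on an aromatic carbon, a change that gave a 10-fold lower number from compound 1 to compound 3 (1.00 log units; beyond the scatter). The place of the change is described in the same words for both pairs, so the two changes are taken as the same.

On this basis compound 4 is expected to sit well below compound 3, with an estimated step of a 200-fold lower number from compound 3 to compound 4 (2.30 log units; beyond the scatter), resting on the earlier step of a 1000-fold lower number from compound 1 to compound 2 (3.00 log units; beyond the scatter). For the measured compounds named here, with only one prior example of the change, the expectation is held loosely and the range kept wide. The estimate for compound 4 in this assay is 0.5 nM, between 0.05 nM and 10 nM.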

Compound 4, effective concentration (reported as EC, without a stated level of effect): 1000 nM
Beside the measured number, compound 4's estimate is 2000-fold (3.30 log units) below it; the measured number lies above the stated range.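

In this assay, the change to 2-fluorophenyl in place of 3-chlorophenyl on a sulfonyl sulfur does not carry from the core of compound 1 to the core of compound 3: the new step, a 10-fold higher number from compound 3 to compound 4 (1.00 log units; beyond the scatter), runs opposite to the earlier one: the same change on two cores in this assay, a 1000-fold lower number (3.00 log units; beyond the scatter) from compound 1 to compound 2 and a 10-fold higher number (1.00 log units; beyond the scatter) from compound 3 to compound 4, 10000-fold (4.00 log units) apart, beyond the scatter of two such steps. The change to methyl in place of methoxy on an aromatic carbon likewise depends on the group on the sulfonyl sulfur, with a 1000-fold higher number from compound 2 to compound 4 (3.00 log units; beyond the scatter) set against the earlier step: the same change on two cores in this assay, a 10-fold lower number (1.00 log units; beyond the scatter) from compound 1 to compound 3 and a 1000-fold higher number (3.00 log units; beyond the scatter) from compound 2 to compound 4, 10000-fold (4.00 log units) apart, beyond the scatter of two such steps. In these four compounds the two changes therefore do not add, but the data do not show why, and one pair per core gives no rule for any other core or group.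

Still open, as far as these compounds go, is whether the methoxy and 2-fluorophenyl pairing in compound 2 is special or whether other groups could match it. An ethyl group on that aromatic carbon, or an unsubstituted phenyl on the sulfonyl sulfur, would help to separate these readings.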